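A few compounds are considered here, and "the series" means these few. Any claim that something is new, unique, unknown or untested is made for them only; others in the source may bear on it.

Compound 2 `Cc1c[nH]c(C(c2ccc(-c3ccc4cccc(F)c4c3)[nH]c2=O)C(C)C)n1` shares its core with compound 1 `CC(C)C(c1cnc(N)s1)c1ccc(-c2ccc3cccc(F)c3c2)[nH]c1=O`; the two differ only in the five-membered ring that sits on a saturated chain carbon bound to an aromatic carbon and a saturated chain carbon. In a functional assay on CHO cells for antagonist activity at prostaglandin E2 receptor EP3 subtype (Homo sapiens), read by cAMP accumulation (a higher number here means a weaker inhibitor, a lower number a stronger inhibitor), compound 1 gives 39 nM, and compound 2 gives 36 nM. The step of a 1.1-fold lower number from compound 1 to compound 2 (0.03 log units; within the scatter) lies within the scatter, so compound 2 stands level with compound 1 and neither can be called the stronger inhibitor.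

Compound 3 `CC(C)C(Cc1noc(=O)[nH]1)c1ccc(-c2ccc3cccc(F)c3c2)[nH]c1=O` changes the same position again: a group of 7 heavy atoms (3 carbon, 2 nitrogen, 2 oxygen; one five-membered aromatic ring with 3 hetero atoms) in place of a group of 6 heavy atoms (4 carbon, 2 nitrogen; one five-membered aromatic ring with 2 hetero atoms), on a saturated chain carbon bound to an aromatic carbon and a saturated chain carbon. Going by the values given here, the only measured step that bears on this exchange is the one from compound 1 to compound 2, where swapping one five-membered ring for another at this place gave a 1.1-fold lower number from compound 1 to compound 2 (0.03 log units; within the scatter), a difference too small to count. That single step suggests this position tolerates a change of ring, so no step beyond the scatter is expected in this assay, but the entering group is also a different kind of ring, which widens the uncertainty.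

For compound 3 the expected value is 50 nM, within a range from 15 nM to 160 nM. This estimate means a step of a 1.4-fold higher number from compound 2 to compound 3 (0.14 log units; within the scatter).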

Compound 3, half-maximal inhibitory concentration: 70 nM
Compound 3: middle estimate off by 1.4-fold (0.15 log units), on the low side, and the stated range covers the measured number.
By their numbers in this assay, from the lowest: compounds 2, 1 and 3 (each within the scatter of the next).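

In this assay, the exchange gives a 1.9-fold higher number from compound 2 to compound 3 (0.29 log units; within the scatter), and set against the 2-amino-1,3-thiazol-5-yl group it gives a 1.8-fold higher number from compound 1 to compound 3 (0.25 log units; within the scatter). Neither step can be read as a real difference, so all three groups placed on a saturated chain carbon bound to an aromatic carbon and a saturated chain carbon stand level within the scatter. The earlier pair compared only five-membered aromatic rings with 2 hetero atoms, whereas compound 3 shows that a larger group of 7 heavy atoms (3 carbon, 2 nitrogen, 2 oxygen), with a ring of 3 hetero atoms, 3 hydrogen-bond acceptors and a double bond outside aromatic rings, also fits this pattern among these three compounds.

No measurement available here accounts for how little the number differs across these exchanges. On these data alone, it remains open whether a carboxylic acid, a simple amine or a longer chain at this place would also stay within the scatter of these three compounds, or whether one of them would finally produce a step that can be read.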